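Pentafluoroalkyl chain homologation in a thiochroman acid series

The source may hold more compounds than are shown below. What is called first, only, known or untested is meant among the compounds shown, and "the series" means these compounds.

The shared core carries a fluorinated acid side chain that varies in the placement of the branch and in the length of the fluorinated arm. Compound 1 `C[C@]1(c2ccc(O)cc2)CSc2cc(O)ccc2[C@H]1CCCCCCCCC(CCCCC(F)(F)C(F)(F)F)C(=O)O` gives 69% in a functional assay on the whole organism for antagonist activity, with Mus musculus as the target, at a dose of 3 mg/kg by the oral route; a lower number here means a weaker effect, a higher number a stronger effect of the compound at the dose given. Compound 2 `C[C@]1(c2ccc(O)cc2)CSc2cc(O)ccc2[C@H]1CCCCCCCCC(CCCCCC(F)(F)C(F)(F)F)C(=O)O` gives 52% in this assay. The change from compound 1 to compound 2 is 2,2,3,3,3-pentafluoropropyl in place of 1,1,2,2,2-pentafluoroethyl on a saturated chain carbon, five bonds along the chain from a carbonyl carbon, and it made a step of a number 17 percentage points lower from compound 1 to compound 2 (beyond the scatter). Compound 3 `C[C@]1(c2ccc(O)cc2)CSc2cc(O)ccc2[C@H]1CCCCCCCCCC(CCCC(F)(F)C(F)(F)F)C(=O)O` gives 45% in this assay; the difference between its core and that of compound 1 is not broken down here, the two having the same atoms joined differently. The values of compound 2 and compound 3 lie within the scatter of each other, so no order is read between them.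

Compound 4 `C[C@]1(c2ccc(O)cc2)CSc2cc(O)ccc2[C@H]1CCCCCCCCCC(CCCCC(F)(F)C(F)(F)F)C(=O)O` has not yet been measured. For the measured compounds named here, it differs from compound 3 by 2,2,3,3,3-pentafluoropropyl in place of 1,1,2,2,2-pentafluoroethyl on a saturated chain carbon, four bonds along the chain from a carbonyl carbon, the same kind of change as between compound 1 and compound 2, though the place lines differ: five bonds along the chain from a carbonyl carbon in the one pair, four bonds along the chain from a carbonyl carbon in the other. A downward step is expected from compound 3 to compound 4 in this assay of about a number 12 percentage points lower from compound 3 to compound 4 (beyond the scatter), because a number 17 percentage points lower from compound 1 to compound 2 (beyond the scatter) was seen for the same kind of change. With the place not identical, a somewhat smaller step than that earlier one is assumed. Compound 4 is therefore estimated at 33% in this assay, with a likely range from 15% to 52%.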

Compound 4, a percentage reported as inhibition, in the whole organism at one dose (the size of the read-out at that dose, not a potency): 53%
Compound 4: the middle estimate sits 20 percentage points below what was measured, outside the stated range (above it).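

Working notes on carrying the change between cores: in this assay, 2,2,3,3,3-pentafluoropropyl in place of 1,1,2,2,2-pentafluoroethyl on a saturated chain carbon, four bonds along the chain from a carbonyl carbon, gives a number 8 percentage points higher from compound 3 to compound 4 (within the scatter), so compound 3 and compound 4 are not told apart by this read-out. The drop seen for the same kind of change on the core of compound 1 therefore does not carry over to the core of compound 3, and the outcome of this change depends on the core that carries it: the same change on two cores in this assay, a number 17 percentage points lower (beyond the scatter) from compound 1 to compound 2 and a number 8 percentage points higher (within the scatter) from compound 3 to compound 4, 25 percentage points apart, beyond the scatter of two such steps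

For the compounds shown here, this rests on only two matched pairs, each read at a single dose, so it does not show that the change is neutral on the core of compound 3, nor does it say which feature of the two cores separates the outcomes.

Still open, from the compounds shown here alone, is whether the same divergence between the two cores would appear with a different end group on the arm, such as trifluoromethyl or heptafluoropropyl, or with a plain unfluorinated alkyl chain. The compounds shown also leave open how an ester or amide in place of the carboxylic acid would behave on either core.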